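This account rests on a few compounds, and the source may have more. Where it says the series, first, only, none or still open, it means among the compounds named here.

Measured in an ADME assay on HepG2 cells (Homo sapiens) for cytotoxicity, read by CellTiter-Glo, with a stated time of 48 h; a higher number here means that more compound is tolerated, a lower number that less compound is tolerated:

Compound 1 `Cc1ccc(-c2nc3cc(Cl)c(Cl)cc3nc2-c2ccccc2)cc1`: > 100000 nM (a limit)
Compound 2 `COc1ccc2nc(NC3CCCCC3)c(S(C)(=O)=O)nc2c1`: 12600 nM
Compound 3 `COc1ccc2nc(S(C)(=O)=O)c(NCCO)nc2c1`: > 100000 nM (a limit)

Compound 3 has no number, only a limit. It sits at the limit of > 100000 nM in this assay, at which 2 of the 3 values shown sit. Compound 4 `COc1ccc2nc(S(C)(=O)=O)c(NCC(C)C)nc2c1` has not yet been measured. It differs from compound 3 in one place, on a saturated chain carbon bound to a nitrogen on an aromatic ring, where isopropyl stands in place of hydroxymethyl, turning 2-hydroxyethyl into isobutyl (isopropyl in place of hydroxymethyl on a saturated chain carbon bound to a nitrogen on an aromatic ring).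

Going by the values given here, no measured pair in the set shows this change directly. Among the compounds with values here, compound 2, at 12600 nM, is the only compound with an actual number in this assay. A moderate shift towards less compound tolerated is therefore expected, though compound 4 could also stay at the limit. The expected step is an at least 2.2-fold lower number from compound 3 to compound 4 (0.34 log units; beyond the scatter), and its size is loose: the starting point is only a limit. For compound 4 the estimated value is 45000 nM, with an expected range of 15000 nM to 100000 nM.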

Compound 4, half-maximal cytotoxic concentration: 79400 nM
Beside the measured number, compound 4's estimate is 1.8-fold (0.25 log units) below it; the range from low to high includes it.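

In this assay compound 4 gives an actual number at this place, 79400 nM, with an isobutyl chain that has none of the hydrogen-bond donors or acceptors of 2-hydroxyethyl. Compound 3 has only a limit, > 100000 nM, and such a limit is common in this set: the limit of > 100000 nM in this assay, at which 2 of the 4 values shown sit.

Isopropyl in place of hydroxymethyl therefore gives an at least 1.2-fold lower number from compound 3 to compound 4 (0.10 log units; that floor lies within the scatter), so the change can be read only as a floor, and whether it truly moves the number beyond the scatter remains unsettled.

The compounds shown leave open whether losing the hydroxymethyl or gaining the isopropyl matters more for this reading. They also leave open how a longer chain, an amine or a carboxylic acid would read in this place.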